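From Hydrogen to Methyl on a Ring Nitrogen

The compounds below may be only part of what the source reports. "The series", "measured", "known", "first", "only" and "open" are said of these compounds alone.

Measured in a functional assay on the whole organism for antagonist activity, with Mus musculus as the target; a higher number here means that more compound is needed for the effect, a lower number that less compound is needed:
Compound 1 `CCOC(=O)N(C)CC#CCn1cncc1C`: 30 mg/kg
Compound 2 `Cc1cncn1CC#CCN1CCNC1=O`: > 100 mg/kg (a limit, not a number)

Compound 2 has no exact value in this assay, and its > 100 mg/kg is only a limit. Compound 3 `Cc1cncn1CC#CCN1CCN(C)C1=O` keeps the rest of that structure and makes one change: methyl in place of hydrogen on an amide-type nitrogen in a ring. Among the compounds with values here, no measured pair in this small set shows what such a change does, so any forecast remains loose. Within the data shown here, the only exact value for comparison comes from compound 1, at 30 mg/kg. A modest shift toward less compound needed in this assay is expected, and the expected size of the step of an at least 1.6-fold lower number from compound 2 to compound 3 (0.22 log units; that floor lies within the scatter) is small. A second limit rather than a number would not be surprising. The estimated value for compound 3 is 60 mg/kg, with an expected range of 25 mg/kg to 150 mg/kg.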

Compound 3, dose for half-maximal effect: > 100 mg/kg
Compound 3: a limit, no number; the forecaster's own chance of this, stated with the estimate: 45%; at least 1.6-fold (0.22 log units) between middle value and limit.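

Compound 2 and compound 3 both give only a limit in this assay, not a number, so no step can be read between them: the limit of > 100 mg/kg in this assay, at which 2 of the 3 values shown sit.

As far as these compounds go, what methyl in place of hydrogen on an amide-type nitrogen in a ring does to the dose needed in this assay remains open.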